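Aryl swap on the double-bonded chain: compound 1 to compound 4

This account rests on a few compounds, and the source may have more. Where it says the series, first, only, none or still open, it means among the compounds named here.

Measured compounds:
compound 1 `Cc1ccc(/C=C/C[C@H]2C[C@@H]([C@@H](O)c3ccccc3)CO[C@@H]2c2ccccc2)cc1C` 10000 nM
compound 2 `COc1ccc(/C=C/C[C@@H]2C[C@@H]([C@@H](O)c3ccc(OC)c(OC)c3)CO[C@H]2c2ccc(OC)c(OC)c2)cc1OC` 30600 nM
compound 3 `COc1cccc([C@@H]2OC[C@H]([C@@H](O)c3ccc(OC)c(OC)c3)C[C@H]2C/C=C/c2ccc(OC)c(OC)c2)c1` 30100 nM

In a functional assay on HeLa cells (Homo sapiens) for cytotoxicity, read by WST assay, with a stated time of 48 h (on this read-out lower numbers stand for stronger inhibition and higher numbers for weaker inhibition), compound 1 gives 10000 nM, the lowest of the three numbers. Compound 3 gives 30100 nM and compound 2 gives 30600 nM, each beyond the scatter from compound 1. Among the measured compounds shown here, the one step measured in one place, a 1.0-fold lower number from compound 2 to compound 3 (0.01 log units; within the scatter), concerns a methoxy on a different aromatic ring and does not bear on the change in hand.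

Compound 4 `O[C@@H](c1ccccc1)[C@H]1CO[C@H](c2ccccc2)[C@@H](C/C=C/c2ccc(F)cc2)C1` differs from compound 1 by 4-fluorophenyl in place of 3,4-dimethylphenyl on a double-bonded chain carbon bound to a double-bonded chain carbon. For the measured compounds named here, no measured step covers this swap on the double-bonded chain carbon, so the expectation rests on compound 1 alone: a step of a 1.2-fold higher number from compound 1 to compound 4 (0.08 log units; within the scatter) of no size beyond the scatter is expected. Compound 4 is estimated at 12000 nM (range 4000 nM to 40000 nM).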

Compound 4, half-maximal inhibitory concentration: 8340 nM
Compound 4: middle estimate off by 1.4-fold (0.16 log units), on the high side, and the stated range covers the measured number.
By their numbers in this assay, from the lowest: compounds 4 and 1 (each within the scatter of the next); then compounds 3 and 2 (each within the scatter of the next).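

In this assay, among the compounds shown here, the step of a 1.2-fold lower number from compound 1 to compound 4 (0.08 log units; within the scatter) is the first read at this position, on a double-bonded chain carbon bound to a double-bonded chain carbon. With 4-fluorophenyl in place of 3,4-dimethylphenyl, the number stays within the scatter, so this pair of aryl groups cannot be told apart in this read-out. No measurement on hand offers an explanation for this result.

On these data alone, whether an amine or a carboxylic acid on this aromatic ring would shift the number remains open. So does the effect of a longer chain carrying the aryl group.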